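The compounds below may be only part of what the source reports. "The series", "measured", "known", "first", "only" and "open" are said of these compounds alone.

Compound 1 `CN(C)c1ncnc2c1c(-c1cc3ccccc3o1)cn2[C@@H]1O[C@H](CO)[C@@H](O)[C@H]1O` and compound 2 `CNc1ncnc2c1c(-c1ccoc1)cn2[C@@H]1O[C@H](CO)[C@@H](O)[C@H]1O` share their core with compound 3 `Cc1ncnc2c1c(-c1ccoc1)cn2[C@@H]1O[C@H](CO)[C@@H](O)[C@H]1O`, and all three were tested in a functional assay on K562 cells (Homo sapiens), read by MTT assay, with a stated time of 72 h; a higher number here means a weaker inhibitor, a lower number a stronger inhibitor. In this assay compound 1 gives only a limit, > 20000 nM. Compound 2 likewise gives only a limit, > 20000 nM. Compound 3 also gives only a limit, > 20000 nM. The step from compound 2 to compound 3 is therefore unreadable, a step that the two limits leave unreadable from compound 2 to compound 3, and nothing fixes where compound 3 stands beyond that limit. Compound 4 `CN(C)c1ncnc2c1c(-c1ccoc1)cn2[C@@H]1O[C@H](CO)[C@@H](O)[C@H]1O` differs from compound 3 by dimethylamino in place of methyl on an aromatic carbon. Among the measured compounds shown here, no measured step of readable size bears on this change; the only guide is the limit of > 20000 nM in this assay, at which 3 of the 3 values shown sit, where every value so far sits. Compound 4 is therefore expected to remain at that limit, with an estimate of 30000 nM ranging from 10000 nM to 100000 nM, which means an expected step that the limit leaves unreadable from compound 3 to compound 4.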

Compound 4, half-maximal inhibitory concentration: 1540 nM
Compound 4: the middle estimate sits 19-fold (1.29 log units) above what was measured; measured number below the stated range.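

In this assay the group on this aromatic carbon decides whether a measurable value appears at all: dimethylamino in place of methyl gives an at least 12-fold lower number from compound 3 to compound 4 (1.11 log units; beyond the scatter), and one further methyl on the nitrogen gives an at least 12-fold lower number from compound 2 to compound 4 (1.11 log units; beyond the scatter). The other substituent counts as well, with furan-3-yl in place of 1-benzofuran-2-yl giving an at least 12-fold lower number from compound 1 to compound 4 (1.11 log units; beyond the scatter). Only compound 4 leaves the limit: the limit of > 20000 nM in this assay, at which 3 of the 4 values shown sit.

As far as these compounds go, whether diethylamino or a pyrrolidine ring on this carbon would hold the gain stays open. So does the exact size of each step, and whether a phenyl ring could stand in for furan-3-yl.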